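A few compounds are considered here, and "the series" means these few. Any claim that something is new, unique, unknown or untested is made for them only; others in the source may bear on it.

Compound 1 `Fc1ccc(C(SCCNC2CCN(Cc3ccccc3)CC2)c2ccc(F)cc2)cc1` gives 32.9 nM in an assay on membranes from striatum (strain Sprague-Dawley) for displacement of a labelled ligand from sodium-dependent dopamine transporter (Rattus norvegicus), read by scintillation counting, with a stated time of 120 min; a lower number here means a stronger inhibitor, a higher number a weaker inhibitor. Compound 2 `[O-][S+](CCNC1CCN(Cc2ccc(F)cc2)CC1)C(c1ccc(F)cc1)c1ccc(F)cc1` gives 50.6 nM in this assay. Compound 3 `OC(Cc1ccccc1)CN1CCC(NCCSC(c2ccc(F)cc2)c2ccc(F)cc2)CC1` gives 31.4 nM in this assay.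

Compound 3 holds the lowest of the three numbers, yet its nearest neighbour is compound 1, and compound 2 is its furthest; both of those gaps fall within the scatter, so the three compounds are not separated in this assay.

The step to compound 4 `Fc1ccc(C(SCCNC2CCN(Cc3cc4ccccc4[nH]3)CC2)c2ccc(F)cc2)cc1` is 1H-indol-2-yl in place of 1-hydroxy-2-phenylethyl on a saturated chain carbon bound to an amine nitrogen in a ring. Among the measured compounds shown here, one measured step bears on this position: a 1.0-fold lower number from compound 1 to compound 3 (0.02 log units; within the scatter), which shows that swapping a phenyl for a 1-hydroxy-2-phenylethyl at this carbon left the number unchanged. For the measured compounds named here, no step exists for a change from phenyl to 1H-indol-2-yl, and compound 2 differs in other places, so its value only shows that the three compounds sit close together. Going by the values given here, since the one change tested at this carbon moved nothing, a 1H-indol-2-yl entering here is expected to stay within the scatter as well, with no direction favoured.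

Compound 4 is therefore estimated at 35 nM, with a range from 12 nM to 100 nM, and the expected step is a 1.1-fold higher number from compound 3 to compound 4 (0.05 log units; within the scatter).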

Compound 4, inhibition constant: 179 nM
Estimate against measurement, compound 4: 5.1-fold (0.71 log units) below, outside the stated range (above it).
By their numbers in this assay, from the lowest: compounds 3, 1 and 2 (each within the scatter of the next); then compound 4.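

In this assay this carbon proves sensitive to what it carries: 1H-indol-2-yl gives a 5.7-fold higher number from compound 3 to compound 4 (0.76 log units; beyond the scatter) and a 5.4-fold higher number from compound 1 to compound 4 (0.74 log units; beyond the scatter), both modest steps towards a weaker inhibitor, whereas the only earlier step here, a 1.0-fold lower number from compound 1 to compound 3 (0.02 log units; within the scatter), had shown no movement. Phenyl and 1-hydroxy-2-phenylethyl therefore stay together, while 1H-indol-2-yl is the first group at this place to separate from them, and it does so although it has the same count of heavy atoms as the 1-hydroxy-2-phenylethyl it replaces. Nothing shown here accounts for this rise in the number.

The compounds shown do not tell whether the rise belongs to the five-membered aromatic ring with its hetero atom or to the fused ring system as a whole, a question that a simple pyridin-2-yl or a naphthalen-2-yl at the same place would address. They also leave open whether a longer chain carrying the 1H-indol-2-yl would stay at the weaker level or return to the level of the phenyl and 1-hydroxy-2-phenylethyl compounds.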